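The source may hold more compounds than are shown below. What is called first, only, known or untested is meant among the compounds shown, and "the series" means these compounds.

Going by the values given here, in a functional assay on HepG2 cells (Homo sapiens) for inhibition, read by MTT assay, with a stated time of 48 h (on this read-out lower numbers stand for stronger inhibition and higher numbers for weaker inhibition), compound 1 `Cc1ccc(-c2nc3ccccn3c2Sc2ccccc2)cc1` gives 67900 nM as the highest of the three numbers so far. Compound 2 `c1ccc(Sc2c(-c3cccc4ccccc34)nc3ccccn23)cc1` gives 9900 nM and compound 3 `Cc1ccc(-c2nc3ccc(C)cn3c2Sc2ccccc2)cc1` gives 14600 nM on the same read-out. Compound 4 `N#Cc1ccc(-c2nc3ccccn3c2Sc2ccccc2)cc1` is still unmeasured and differs from compound 1 by cyano in place of methyl on an aromatic carbon in one change: cyano in place of methyl on an aromatic carbon, para to a large group. Among the compounds with values here, the only measured one-place step is a 4.7-fold lower number from compound 1 to compound 3 (0.67 log units; beyond the scatter) and it is modest, but it puts methyl in place of hydrogen elsewhere in the molecule, so it bears only loosely on this change. Within the data shown here, with compound 1 at 67900 nM as the top number, a modest move to a lower number is expected, though no measured step tests this change directly. The expected size is a 1.9-fold lower number from compound 1 to compound 4 (0.29 log units; within the scatter) as an estimate only. The estimate for compound 4 is 35000 nM within an expected range of 11000 nM to 100000 nM for repeat measurements.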

Compound 4, half-maximal inhibitory concentration: 15700 nM
Compound 4: the middle estimate sits 2.2-fold (0.35 log units) above what was measured; the range from low to high includes it.
By their numbers in this assay, from the lowest: compounds 2, 3 and 4 (each within the scatter of the next); then compound 1.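

In this assay, the place on the six-membered carbon ring, para to a large group, responds to a swap of one group for another: 4-methylphenyl to 4-cyanophenyl gives a 4.3-fold lower number from compound 1 to compound 4 (0.64 log units; beyond the scatter). The earlier step added a methyl elsewhere in the molecule, so it said nothing about this place, and the methyl here can clearly be replaced without the number rising. Nothing measured here gives a cause for this step.

As far as these compounds go, whether an amine, a carboxylic acid or a longer chain at this place would lower the number further or raise it remains open. So does the outcome of pairing the nitrile with the extra methyl of compound 3.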